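Chloro on the distal ring of the compound 1 series

The source may report more compounds than this note shows. Statements on the series, on what has been measured and on what is new or still open speak of the compounds shown alone.

Measured so far in a functional assay for agonist activity at G protein-coupled receptor 88 (Homo sapiens), read by HTRF and cAMP accumulation; on this read-out higher numbers stand for an effect only at larger amounts of compound and lower numbers for an effect already at smaller amounts:
- compound 1 `CC(C)C[C@H](N)CN(C(=O)[C@@H]1C[C@H]1c1ccccc1)c1ccc(-c2ccccc2)cc1` gives 880 nM
- compound 2 `NC1(CN(C(=O)[C@@H]2C[C@H]2c2ccccc2)c2ccc(-c3ccccc3)cc2)CCCC1` gives 0.57 nM
- compound 3 `O=C([C@@H]1C[C@H]1c1ccccc1)N(CCNCC1CCCC1)c1ccc(-c2ccccc2)cc1` gives 2.5 nM

Compound 1 stands at the highest number of the three. Both steps away from it are large: a 1500-fold lower number from compound 1 to compound 2 (3.19 log units; beyond the scatter) and a 350-fold lower number from compound 1 to compound 3 (2.55 log units; beyond the scatter). Both of these, like the modest step of a 4.4-fold higher number from compound 2 to compound 3 (0.64 log units; beyond the scatter), change only the group on the saturated chain carbon bound to the amide-type nitrogen; the biphenyl part is the same throughout.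

Compound 4 `CC(C)C[C@H](N)CN(C(=O)[C@@H]1C[C@H]1c1ccccc1)c1ccc(-c2ccccc2Cl)cc1` differs from compound 1 at that untouched part: chloro in place of hydrogen on an aromatic carbon. Among the compounds with values here, no measured step bears on a change at this ring, so the measured steps give no direction for it. With nothing in the series pointing either way, the expected step in this assay from compound 1 to compound 4 is none beyond the scatter, that is no change at the digits printed from compound 1 to compound 4 (within the scatter), with a wide range to cover the lack of any comparable step. Compound 4 is therefore estimated at 880 nM, expected between 250 nM and 3000 nM.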

Compound 4, half-maximal effective concentration: 3800 nM
For compound 4 the middle estimate is 4.3-fold (0.64 log units) below the measured one, and the stated range ends below it.
By their numbers in this assay, from the lowest: compound 2; then compound 3; then compound 1; then compound 4.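

In this assay, the ring that carries the change is not a silent position: 2-chlorophenyl in place of phenyl gives a 4.3-fold higher number from compound 1 to compound 4 (0.64 log units; beyond the scatter), the first step measured at this ring. That step is modest compared with the large changes on the saturated chain carbon, a 1500-fold lower number from compound 1 to compound 2 (3.19 log units; beyond the scatter) and a 350-fold lower number from compound 1 to compound 3 (2.55 log units; beyond the scatter), so among these compounds the chain group moves the number much further than this single chloro does. No measurement offered here accounts for the direction of the chloro step.

On these data alone, whether chloro has a similar effect with the 1-aminocyclopentyl group of compound 2 or the ((cyclopentylmethyl)amino)methyl group of compound 3 remains open. Also open, as far as these compounds go, is how fluoro, methyl or methoxy in the same place would compare with chloro.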